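Shifting the chloro group: from compound 2 to compound 3

A few compounds are considered here, and "the series" means these few. Any claim that something is new, unique, unknown or untested is made for them only; others in the source may bear on it.

compound 1 `CC(C)=CCOc1cc(O)c2c(c1)OC(c1ccccc1)CC2=O` gives 7320 nM
compound 2 `CC(C)=CCOc1cc(O)c2c(c1)OC(c1cccc(Cl)c1)CC2=O` gives 6060 nM
compound 3 `CC(C)=CCOc1cc(O)c2c(c1)OC(c1ccc(Cl)cc1)CC2=O` has not yet been measured

Going by the values given here, in a functional assay (a lower number here means a stronger inhibitor, a higher number a weaker inhibitor), compound 2 gives 6060 nM and stands within the scatter of compound 1, the only other measured compound. Compound 3 carries 4-chlorophenyl in place of 3-chlorophenyl on a saturated ring carbon, with the same atoms joined differently. Among the compounds with values here, the only measured step that bears on this is chloro in place of hydrogen on an aromatic carbon, a 1.2-fold lower number from compound 1 to compound 2 (0.08 log units; within the scatter) and so within the scatter. Within the data shown here, no measured compound carries the 4-chlorophenyl group, so the data give no direct reading of it. With that one step so small, no step beyond the scatter is expected in this assay in either direction. The estimated step of a 1.0-fold lower number from compound 2 to compound 3 (0.00 log units; within the scatter) is therefore small. For compound 3 the estimated value is 6000 nM with a range from 2800 nM to 13000 nM as the expected span.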

Compound 3, half-maximal inhibitory concentration: 7020 nM
For compound 3 the middle estimate is 1.2-fold (0.07 log units) below the measured one; measured number inside the range.
By their numbers in this assay, from the lowest: compounds 2, 3 and 1 (each within the scatter of the next).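

In this assay, 4-chlorophenyl in place of 3-chlorophenyl on the saturated ring carbon next to the ring oxygen comes to a 1.2-fold higher number from compound 2 to compound 3 (0.06 log units; within the scatter) and so lies within the scatter, which means the two chlorophenyl groups cannot be told apart here. Set against the unsubstituted phenyl group, the new chlorophenyl group gives a 1.0-fold lower number from compound 1 to compound 3 (0.02 log units; within the scatter), so chloro in place of hydrogen on an aromatic carbon now stays within the scatter for two chlorophenyl groups, where the earlier compounds offered only one. Nothing available accounts for how closely these three compounds agree.

The compounds shown leave open whether a methoxy group, a hydroxyl group or an amine on this phenyl ring would shift the number beyond the scatter. On these data alone, it is equally open what a longer chain or a carboxylic acid would do in place of the ether side chain on the shared core.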